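The compounds below may be only part of what the source reports. "The series", "measured", "known", "first", "only" and "open" are said of these compounds alone.

Of the compounds shown here, two have been measured so far in a functional assay on CHO-K1 cells for agonist activity at Glucose-dependent insulinotropic receptor (Homo sapiens), read by a luciferase reporter, with a stated time of 5 h; on this read-out higher numbers stand for an effect only at larger amounts of compound and lower numbers for an effect already at smaller amounts. Compound 1, with the structure `CC(C)OC(=O)N1CCC(Oc2cccc3c2CCN3c2ccc(S(C)(=O)=O)cc2)CC1`, gives 501 nM in this assay. Compound 2, with the structure `CC(C)OC(=O)N1CCC(Oc2ncnc3c2CCN3c2ccc(S(C)(=O)=O)cc2)CC1`, gives 126 nM, the lower of the two numbers, and the gap from compound 1 to compound 2 lies beyond the usual scatter of repeated measurements, so compound 2 acts at smaller amounts than compound 1.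

Compound 3, with the structure `CC(C)OC(=O)N1CCC(Oc2ncnc3c2CCN3c2ccc(F)cn2)CC1`, has not yet been measured. It differs from compound 2 in one place: 5-fluoropyridin-2-yl in place of 4-(methylsulfonyl)phenyl on a nitrogen on an aromatic ring in a ring. Going by the values given here, no measured pair shows this same change, so there is no step from which its size could be read directly. The change is substantial in what it removes and what it brings in, and a shift in this assay is expected rather than none at all. The step from compound 2 to compound 3 is expected to move toward a higher number, of the size given by a 2.8-fold higher number from compound 2 to compound 3 (0.44 log units; beyond the scatter). Compound 3 is accordingly estimated at 350 nM, within a range from 100 nM to 1500 nM.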

Compound 3, half-maximal effective concentration: > 10000 nM
Compound 3 was reported as a limit; the forecaster's own chance of this, stated with the estimate: 10%; middle value at least 28-fold (1.45 log units) from the limit.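

The value for compound 3 is a limit of the assay, not a number: the limit of > 10000 nM in this assay, at which 1 of the 3 values shown sits. On the nitrogen of the five-membered ring, replacing 4-(methylsulfonyl)phenyl with 5-fluoropyridin-2-yl gives an at least 79-fold higher number from compound 2 to compound 3 (1.89 log units; beyond the scatter), a large step in this assay. Both earlier compounds carry 4-(methylsulfonyl)phenyl at this place, so they gave no view of any other group there; this result shows that the reading in this assay can depend heavily on the group at this position, and that 5-fluoropyridin-2-yl does not stand in for 4-(methylsulfonyl)phenyl on the core of compound 2.

The change alters the ring and its substituent together, so the compounds shown cannot separate the loss of the methylsulfonyl group from the arrival of the ring nitrogen and the fluorine. Going by these compounds, a pyridin-2-yl ring carrying methylsulfonyl, or a phenyl ring carrying a nitrile or an amide, would pull these parts apart, and how any of these groups would behave at this position remains open.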